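Hydrazone Aryl Swap in the Shared Core: Compound 3 Outlook

This account rests on a few compounds, and the source may have more. Where it says the series, first, only, none or still open, it means among the compounds named here.

Measured so far:
compound 1 `CN(C)CCn1cnnc1-c1cc(Oc2ccc(NC(=O)N/N=C/c3c[nH]c4ccccc34)cc2F)ccn1` — 790 nM
compound 2 `COc1cc(/C=N/NC(=O)Nc2ccc(Oc3ccnc(-c4nncn4CCN(C)C)c3)c(F)c2)cc(OC)c1OC` — 2900 nM

In a functional assay on MKN-45 cells (Homo sapiens) for cytotoxicity, read by MTT assay, with a stated time of 72 h (a lower number here means a stronger inhibitor, a higher number a weaker inhibitor), compound 1 gives 790 nM, the lowest of the two numbers recorded; in the same assay compound 2 gives 2900 nM. Within the data shown here, the one step measured is a 3.7-fold higher number from compound 1 to compound 2 (0.56 log units; beyond the scatter), so exchanging the group on the carbon with a double bond to nitrogen for a methoxy-bearing phenyl ring weakened the inhibitor in this assay.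

Compound 3 `COc1ccc(/C=N/NC(=O)Nc2ccc(Oc3ccnc(-c4nncn4CCN(C)C)c3)c(F)c2)cc1O` is unmeasured. It differs from compound 1 as follows: 3-hydroxy-4-methoxyphenyl in place of 1H-indol-3-yl on a carbon with a double bond to nitrogen. Among the measured compounds shown here, the only step that bears on this change is the one from compound 1 to compound 2, which replaced the same group with a different oxygen-substituted phenyl ring and gave a 3.7-fold higher number from compound 1 to compound 2 (0.56 log units; beyond the scatter). A comparable loss is therefore expected, with the estimated step being a 2.5-fold higher number from compound 1 to compound 3 (0.40 log units; beyond the scatter). In this assay compound 3 is expected to give about 2000 nM, within a range of 800 nM to 5000 nM.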

Compound 3, half-maximal inhibitory concentration: 2510 nM
Estimate against measurement, compound 3: 1.3-fold (0.10 log units) below, within the range that was stated.
By their numbers in this assay, from the lowest: compound 1; then compounds 3 and 2 (each within the scatter of the next).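

In this assay, a second oxygen-substituted phenyl ring on the carbon with a double bond to nitrogen also falls short of 1H-indol-3-yl, with a 3.2-fold higher number from compound 1 to compound 3 (0.50 log units; beyond the scatter) on this change, so among these three compounds the loss is not confined to 3,4,5-trimethoxyphenyl. Exchanging that ring for 3-hydroxy-4-methoxyphenyl gives a 1.2-fold lower number from compound 2 to compound 3 (0.06 log units; within the scatter) and so does not separate the two phenyl rings in this read-out. Nothing available accounts for the difference between 1H-indol-3-yl and either phenyl ring.

Still open, as far as these compounds go, is whether an unsubstituted phenyl or a pyridyl group at this carbon would give a number closer to that of compound 1 or to those of compound 2 and compound 3. Also open, from the compounds shown here alone, is how a methoxy group on the 1H-indol-3-yl group would behave.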